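Removing a methyl from a hydroxy-naphthyl-naphthyridine core

This account rests on a few compounds, and the source may have more. Where it says the series, first, only, none or still open, it means among the compounds named here.

Compound 1: `Oc1cc(-c2ccc3ccccc3c2)nc2ncccc12` gives 8130 nM
Compound 2: `Cc1cc(C)c2c(O)cc(-c3cccc4ccccc34)nc2n1` gives 1050 nM
Compound 3: `Cc1ccc2c(O)cc(-c3ccc4ccccc4c3)nc2n1` gives 4570 nM

Of the compounds shown here, three have been measured in a functional assay on cells (Tumor Cell line, Homo sapiens) for antiproliferative activity; on this read-out higher numbers stand for weaker inhibition of growth and lower numbers for stronger inhibition of growth. Compound 2 gives the lowest number of the three; compound 3 is nearest to it and compound 1 is furthest, both gaps lying beyond the scatter. Compound 3 and compound 1 differ in one place: hydrogen in place of methyl on an aromatic carbon. That change made a step of a 1.8-fold higher number from compound 3 to compound 1 (0.25 log units; within the scatter), which is within the scatter. How the core of compound 2 differs from that of compound 3 is not broken down here.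

Compound 4, `Cc1ccc2c(O)cc(-c3cccc4ccccc34)nc2n1`, has not yet been measured in this assay. It differs from compound 2 in one place: hydrogen in place of methyl on an aromatic carbon. This is the same kind of change as that from compound 3 to compound 1, but the surroundings are not the same: in compound 3 the methyl that leaves sits next to the ring nitrogen and meta and para to a fused ring, whereas in compound 2 it sits opposite the ring nitrogen, ortho and meta to a fused ring, and meta to another methyl group. Within the data shown here, the only measured example of this kind of change, a 1.8-fold higher number from compound 3 to compound 1 (0.25 log units; within the scatter), stayed within the scatter, so a step of similar size is expected from compound 2 to compound 4, estimated as a 1.9-fold higher number from compound 2 to compound 4 (0.28 log units; within the scatter). Because compound 2 gives 1050 nM, compound 4 is estimated at 2000 nM, expected to fall between 900 nM and 5000 nM.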

Compound 4, concentration for 50% growth inhibition: 66.1 nM
Compound 4: the middle estimate sits 30-fold (1.48 log units) above what was measured, outside the stated range (below it).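

In this assay, putting hydrogen in place of the methyl opposite the ring nitrogen of compound 2 gave a large step, a 16-fold lower number from compound 2 to compound 4 (1.20 log units; beyond the scatter), so compound 4 emerges as the strongest inhibitor of growth among the four compounds at 66.1 nM. Set beside the earlier example, this shows that the size of the step did not carry over from one core to the other: the same change on two cores in this assay, a 1.8-fold higher number (0.25 log units; within the scatter) from compound 3 to compound 1 and a 16-fold lower number (1.20 log units; beyond the scatter) from compound 2 to compound 4, 28-fold (1.45 log units) apart, beyond the scatter of two such steps. It does not show which difference between the two cores, or between the surroundings of the two methyl groups, sets the steps apart, and two pairs give no rule for what the change would do on any further core.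

Still open, as far as these compounds go, is how a longer chain, a methoxy group, an amine or a chlorine atom on that same aromatic carbon would compare with the hydrogen of compound 4 and the methyl of compound 2. Also open, from the compounds shown here alone, is whether the methyl group that remains on compound 4 contributes to its low number, and whether a step of this size would appear on other cores of the series or in other tumor cell lines.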